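The source may report more compounds than this note shows. Statements on the series, on what has been measured and on what is new or still open speak of the compounds shown alone.

Measured so far:
compound 1 `CC(=O)Nc1c(C(O)(C(F)(F)F)C(F)(F)F)ccc2ccccc12`: 95.5 nM
compound 2 `CCCC(=O)Nc1c(C(O)(C(F)(F)F)C(F)(F)F)ccc2ccccc12`: 708 nM

In a functional assay (Sus scrofa) with sulfonylurea receptors; K-ATP channels (Homo sapiens) as the target (a lower number here means that less compound is needed, a higher number that more compound is needed for the effect), compound 1 gives 95.5 nM and compound 2 gives 708 nM, the higher of the two numbers. Going by the values given here, the single step in hand is a 7.4-fold higher number from compound 1 to compound 2 (0.87 log units; beyond the scatter); growing the chain on the carbonyl carbon raised the number. Compound 3 `CC(C)=CC(=O)Nc1c(C(O)(C(F)(F)F)C(F)(F)F)ccc2ccccc12` carries the change (2-methylprop-1-en-1-yl in place of propyl on a carbonyl carbon). Given a 7.4-fold higher number from compound 1 to compound 2 (0.87 log units; beyond the scatter), compound 3 is expected to stay near compound 2, with no step beyond the scatter: a 1.1-fold higher number from compound 2 to compound 3 (0.05 log units; within the scatter). The estimate for compound 3 in this assay is 800 nM, range 250 nM to 2500 nM.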

Compound 3, half-maximal effective concentration: 550 nM
Compound 3: the middle estimate sits 1.5-fold (0.16 log units) above what was measured, and the stated range covers the measured number.
By their numbers in this assay, from the lowest: compound 1; then compounds 3 and 2 (each within the scatter of the next).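

In this assay the step of a 1.3-fold lower number from compound 2 to compound 3 (0.11 log units; within the scatter) puts 2-methylprop-1-en-1-yl level with propyl on this carbonyl carbon, so swapping in that group with its double bond leaves the reading unresolved from propyl. The step of a 5.8-fold higher number from compound 1 to compound 3 (0.76 log units; beyond the scatter) shows that the higher number relative to methyl is not confined to propyl: a second group at the same place carries it too. No supporting data bear on the reason for either step.

As far as these compounds go, still open: whether ethyl, a longer chain, or a chain ending in an amine or a carboxylic acid on this carbonyl carbon would read closer to compound 1 or further from it.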